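The compounds below may be only part of what the source reports. "The series", "measured", "known", "first", "only" and "open" are said of these compounds alone.

Compounds measured so far:

Compound 1, `COc1cc(-c2ccnc3cc(-c4cn(CO)c5ccccc45)nn23)cc(OC)c1OC`, gives 103 nM in a functional assay on HeLa cells (Homo sapiens) for inhibition, read by CCK-8 assay, with a stated time of 48 h; on this read-out lower numbers stand for stronger inhibition and higher numbers for weaker inhibition.
Compound 2, `Cn1ccc2cc(-c3cc4nccc(-c5ccc(F)cc5)n4n3)ccc21`, gives 5210 nM in this assay.
Compound 3, `COc1cc(-c2ccnc3cc(-c4cccc(C#N)c4)nn23)cc(OC)c1OC`, gives > 10000 nM in this assay.

The value given for compound 3 is a limit of the assay and not a number; it stands at the limit of > 10000 nM in this assay, at which 1 of the 3 values shown sits. Among the compounds with values here, of the three compounds, compound 3 is the one without a measured value, so its position can only be described as being at that limit, while compound 1 and compound 2 each have a number.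

The next compound, compound 4, is `COc1cc(-c2ccnc3cc(-c4ccc5cnn(C)c5c4)nn23)cc(OC)c1OC`. It differs from compound 3 in one place: 1-methyl-1H-indazol-6-yl in place of 3-cyanophenyl on an aromatic carbon. The trimethoxyphenyl part of compound 3 is kept, and a fused two-ring group enters where a single six-membered ring stood. Compound 1 also carries a fused two-ring group on the same side of the shared core together with the trimethoxyphenyl part, and compound 1 gives 103 nM. Compound 3, by contrast, sits at its limit. On that basis a step toward stronger inhibition is expected in this assay from compound 3 to compound 4, well beyond the scatter, of about an at least 25-fold lower number from compound 3 to compound 4 (1.39 log units; beyond the scatter). Compound 4 is therefore estimated at 400 nM, with a likely range from 80 nM to 4000 nM.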

Compound 4, half-maximal inhibitory concentration: 97 nM
The estimate for compound 4 lay 4.1-fold (0.62 log units) above the measured number; the measured number falls inside the stated range.
By their numbers in this assay, from the lowest: compounds 4 and 1 (each within the scatter of the next); then compound 2. At a limit, above all of these: compound 3.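

Within the data shown here, replacing 3-cyanophenyl with 1-methyl-1H-indazol-6-yl on this aromatic carbon of the five-membered ring gives the first change at this place that can be read alone: an at least 100-fold lower number from compound 3 to compound 4 (2.01 log units; beyond the scatter) in this assay. Compound 3 carries a limit of the assay and not a number, so this step gives only a minimum size: the limit of > 10000 nM in this assay, at which 1 of the 4 values shown sits. With the trimethoxyphenyl part kept, compound 1 gives 103 nM and compound 4 gives 97 nM, two values within the usual scatter of each other, so among these three compounds, the two with a fused two-ring group at this place share this range, while the single ring of compound 3 does not.

On these data alone, what stays open is which part of the 1-methyl-1H-indazol-6-yl group matters: the ring nitrogens, the methyl or the second ring itself. As far as these compounds go, it is also open whether a single six-membered ring carrying an amine or a carboxylic acid in place of the nitrile would reach the same range in this assay.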